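The source may report more compounds than this note shows. Statements on the series, on what has been measured and on what is new or still open speak of the compounds shown alone.

Working notes on the series, all read in a functional assay on KB cells (Homo sapiens) for antiproliferative activity, read by sulforhodamine B assay, with a stated time of 3 days; a higher number here means that more compound is needed for the effect, a lower number that less compound is needed. Compound 1 (`CCCC1=C(OC)C(CCC)(CCC)C(=O)/C(=C(O)\C=C\c2ccccc2)C1=O`) gives 4.6 uM, compound 2 (`CCCC1=C(OC)C(CCC)(CCC)C(=O)/C(=C(O)\C=C\c2ccc(I)cc2)C1=O`) gives 1.5 uM, and compound 3 (`CCCC1=C(OCCC(C)C)C(CCC)(CCC)C(=O)/C(=C(O)\C=C\c2ccccc2)C1=O`) gives 10.6 uM, the highest number of the three.

Compound 4 (`CCCC1=C(OCC(C)C)C(CCC)(CCC)C(=O)/C(=C(O)\C=C\c2ccccc2)C1=O`) differs from compound 3 only in the ether chain: isopropyl in place of isobutyl on a saturated chain carbon bound to an oxygen on an unsaturated carbon. In words, isopropyl stands in place of isobutyl on a saturated chain carbon bound to an oxygen on an unsaturated carbon, which reads as isopentyloxy to isobutoxy.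

The measured step at this place is a 2.3-fold higher number from compound 1 to compound 3 (0.36 log units; beyond the scatter), a modest one. The other measured step, a 3.1-fold lower number from compound 1 to compound 2 (0.49 log units; beyond the scatter), is a change on an aromatic carbon and does not bear on this comparison. Compound 4 keeps most of the chain that compound 1 lacks, so only a small part of the step to compound 3 is expected to reverse. The expected change is small, towards a lower number and within the scatter: an estimated 1.3-fold lower number from compound 3 to compound 4 (0.12 log units; within the scatter). For compound 4 the expected value is 8 uM, with an estimated range of 4.5 uM to 14 uM.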

Compound 4, concentration for half-maximal effect: 4.8 uM
Estimate against measurement, compound 4: 1.7-fold (0.22 log units) above; measured number inside the range.
By their numbers in this assay, from the lowest: compound 2; then compounds 1 and 4 (each within the scatter of the next); then compound 3.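

Within this assay, the change from isopentyloxy to isobutoxy gives a 2.2-fold lower number from compound 3 to compound 4 (0.34 log units; beyond the scatter) and so is a step beyond the scatter, which compound 1 and compound 3 alone could not show. Compound 4 then gives a 1.0-fold higher number from compound 1 to compound 4 (0.02 log units; within the scatter) within the scatter, so among these three compounds the isobutoxy chain is tolerated on the shared core and the higher number appears only with isopentyloxy. No measurement at hand bears on why the number moves at this place.

As far as these compounds go, whether the iodo step seen on the phenyl-bearing side chain of compound 2 carries over to the isobutoxy or isopentyloxy compounds remains open. Also open, from the compounds shown here alone, is how a chain longer than isopentyl, or an amine or a carboxylic acid in the ether chain, would read in this assay.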